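This account rests on a few compounds, and the source may have more. Where it says the series, first, only, none or still open, it means among the compounds named here.

Of the compounds shown here, two with a shared core have been tested in a functional assay on MOLT-4 cells (Homo sapiens) for cytotoxicity, read by MTT assay, with a stated time of 72 h; on this read-out higher numbers stand for weaker inhibition and lower numbers for stronger inhibition. Compound 1 `COc1cccc(COc2ccc3cc(C(=O)/C=C/c4ccc(C)cc4)c(=O)oc3c2)c1` carries a methyl on an aromatic carbon. In this assay compound 1 gives > 50000 nM, which is a limit of the assay rather than a number, the limit described as the limit of > 50000 nM in this assay, at which 1 of the 2 values shown sits. Compound 2 `COc1cccc(COc2ccc3cc(C(=O)/C=C/c4ccccc4)c(=O)oc3c2)c1` has hydrogen in place of that methyl. In this assay compound 2 gives > 100000 nM, again a limit and not a number, the limit described as the limit of > 100000 nM in this assay, at which 1 of the 2 values shown sits. The step that the two limits leave unreadable from compound 1 to compound 2 lies between two limits and cannot be read in size or direction. Compound 2 thus stands at a limit of this assay, with no number of its own. Compound 3 `COc1cccc(COc2ccc3cc(C(=O)/C=C/c4cccc(OC)c4OC)c(=O)oc3c2)c1` is the next compound, differing from compound 2 by 2,3-dimethoxyphenyl in place of phenyl on a double-bonded chain carbon bound to a double-bonded chain carbon. Among the compounds with values here, no measured step bears on this change, as the only step available gives neither a size nor a direction. Compound 3 is expected to remain near a limit of this assay, estimated at 70000 nM with a range from 20000 nM to 200000 nM. The expected step is an at least 1.4-fold lower number from compound 2 to compound 3 (0.15 log units; that floor lies within the scatter), nothing beyond the scatter.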

Compound 3, half-maximal inhibitory concentration: 22800 nM
Estimate against measurement, compound 3: 3.1-fold (0.49 log units) above, and the stated range covers the measured number.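

Swapping the aromatic group at this position, on a double-bonded chain carbon bound to a double-bonded chain carbon, can move the read-out in this assay: 2,3-dimethoxyphenyl in place of phenyl gives an at least 4.3-fold lower number from compound 2 to compound 3 (0.64 log units; beyond the scatter), and in place of 4-methylphenyl it gives an at least 2.1-fold lower number from compound 1 to compound 3 (0.34 log units; beyond the scatter). The earlier step could not be read, so these are the first steps here with a direction, both toward stronger inhibition and both floors rather than full sizes, as compound 2 has only a limit and no number of its own: the limit of > 100000 nM in this assay, at which 1 of the 3 values shown sits. Compound 1 likewise has only a limit: the limit of > 50000 nM in this assay, at which 1 of the 3 values shown sits.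

The compounds shown leave open whether both methoxy groups are needed for this change, as a phenyl with a single methoxy is not among them, and neither is a ring with a different pair of methoxy placements. They also leave open whether the oxygen atoms matter or other groups on this ring, such as an amine or a carboxylic acid, would move the read-out in the same direction.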